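The compounds below may be only part of what the source reports. "The series", "measured", "known", "first", "only" and "open" are said of these compounds alone.

The measured compounds are:

compound 1 `COc1cc(NC(=O)Nc2cc(Nc3ccc(OC)c(C)c3)ncn2)cc(OC)c1` — 48.3%
compound 2 `Cc1ccc(Nc2cc(NC(=O)Nc3c(Cl)cccc3Cl)ncn2)cc1C` — 84.3%

In a functional assay on HCC827 cells (Homo sapiens) for inhibition, read by MTT assay, with a stated time of 48 h, tested at 10 uM (a lower number here means less inhibition, a higher number more inhibition at the concentration tested (going by the name of the read-out)), compound 1 gives 48.3%, the lowest of the two numbers. Its nearest neighbour, compound 2, gives 84.3%, a number higher by a margin beyond the usual scatter; the two compounds differ in more than one place, so their values are reported side by side without any single change being traced between them.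

Compound 3 `COc1cc(NC(=O)Nc2cc(Nc3cc(F)ccc3OC)ncn2)cc(OC)c1` has not yet been measured in this assay. It differs from compound 1 in one place: 5-fluoro-2-methoxyphenyl in place of 4-methoxy-3-methylphenyl on a nitrogen on an aromatic ring

Among the compounds with values here, no measured pair shows a change of this kind, so there is no step from which to read the size of its effect. The step of a number 3.3 percentage points lower from compound 1 to compound 3 (within the scatter) is therefore expected to be small, within the scatter, in no set direction. Compound 3 is accordingly expected to give about 45%, within a range from 25% to 65%.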

Compound 3, a percentage reported as inhibition, at one concentration (the size of the read-out at that concentration, not a potency): 59%
The estimate for compound 3 lay 14 percentage points below the measured number; measured number inside the range.
By their numbers in this assay, from the lowest: compound 1; then compound 3; then compound 2.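

In this assay, within the data shown here, this is the first step read at the place on a nitrogen on an aromatic ring: 5-fluoro-2-methoxyphenyl in place of 4-methoxy-3-methylphenyl gives a number 10.7 percentage points higher from compound 1 to compound 3 (beyond the scatter). The read-out therefore responds to the group at this place, if only modestly, even though the two groups match in heavy atoms, hydrogen-bond donors, hydrogen-bond acceptors and net charge. Nothing at hand accounts for the size or direction of this step.

As far as these compounds go, the change alters several things at once, and it remains open whether the fluoro group, the loss of the methyl group or the new placement of the methoxy group carries the step. Also open, from the compounds shown here alone, is how this place would respond to a phenyl ring bearing an amine or a carboxylic acid, or to a longer chain in place of the methoxy group.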